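Swapping Methyl for Bromo on an Indole-Bearing Diterpenoid Ester

The source may report more compounds than this note shows. Statements on the series, on what has been measured and on what is new or still open speak of the compounds shown alone.

Compound 1 `COC(=O)[C@@]1(C)CCC=C2[C@@H]1CC[C@@H](C)[C@]2(C)Cc1c[nH]c2ccccc12` and compound 2 `COC(=O)[C@@]1(C)CCC=C2[C@@H]1CC[C@@H](C)[C@]2(C)Cc1c[nH]c2ccc(C)cc12` share one core and differ only in a methyl added on an aromatic carbon of the indole ring. Among the compounds with values here, in a functional assay on A549 cells (Homo sapiens) for inhibition, read by sulforhodamine B assay, with a stated time of 48 h (on this read-out lower numbers stand for stronger inhibition of growth and higher numbers for weaker inhibition of growth), compound 1 gives 5000 nM, while compound 2 gives 17000 nM; the step of a 3.4-fold higher number from compound 1 to compound 2 (0.53 log units; beyond the scatter) is modest but real, and compound 2 therefore holds the higher of the two numbers so far. Compound 3 `COC(=O)[C@@]1(C)CCC=C2[C@@H]1CC[C@@H](C)[C@]2(C)Cc1c[nH]c2ccc(Br)cc12` takes the next step: bromo in place of methyl on an aromatic carbon. Within the data shown here, no measured pair shows bromo against methyl, so the only guide is that the methyl step in this assay was a 3.4-fold higher number from compound 1 to compound 2 (0.53 log units; beyond the scatter). A change of similar size in either direction, or none beyond the scatter, is therefore expected for the bromo compound. Compound 3 is estimated to give 12000 nM, within a range of 4000 nM to 36000 nM, a step of a 1.4-fold lower number from compound 2 to compound 3 (0.15 log units; within the scatter).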

Compound 3, concentration for 50% growth inhibition: 15000 nM
Estimate against measurement, compound 3: 1.3-fold (0.10 log units) below, and the stated range covers the measured number.
By their numbers in this assay, from the lowest: compound 1; then compounds 3 and 2 (each within the scatter of the next).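

A step of a 1.1-fold lower number from compound 2 to compound 3 (0.05 log units; within the scatter) in this assay means that bromo and methyl cannot be told apart on this aromatic carbon. Bromo in place of hydrogen gives a 3.0-fold higher number from compound 1 to compound 3 (0.48 log units; beyond the scatter) as a modest step, so both groups shown here give weaker growth inhibition than the hydrogen of compound 1. Nothing reported alongside these numbers explains this result.

From the compounds shown here alone, whether any group on this carbon can match or improve on hydrogen remains open, and an amine, a methoxy group or a carboxylic acid could fall on either side of compound 1. Going by these compounds, what the same groups would do on the other aromatic carbons of this ring is also open.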